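This account rests on a few compounds, and the source may have more. Where it says the series, first, only, none or still open, it means among the compounds named here.

Measured compounds:
compound 1 `Cc1c(OCCCCOc2cccc(C(=O)O)c2)ccc(C(=O)CC(C)C)c1C`: "not active" (no number reported)
compound 2 `Cc1c(OCCCCOc2ccc(C(=O)O)cc2)ccc(C(=O)CC(C)C)c1O`: 122 nM
compound 3 `Cc1c(OCCCCOc2ccc(C(=O)O)cc2)ccc(C(=O)CC2CCCC2)c1O`: 824 nM

In an assay on HEK293 cells for positive allosteric modulation of metabotropic glutamate receptor 2 (Rattus norvegicus), read by thallium flux, with a stated time of 2.5 min (on this read-out higher numbers stand for an effect only at larger amounts of compound and lower numbers for an effect already at smaller amounts), compound 1 returned no number at all. Going by the values given here, compound 3 holds the highest of the two numbers reported; the one recorded step leading to it is a 6.8-fold higher number from compound 2 to compound 3 (0.83 log units; beyond the scatter). Compound 4 `Cc1cc(C(=O)O)ccc1OCCCCOc1ccc(C(=O)CC2CCCC2)c(O)c1C` differs from compound 3 by methyl in place of hydrogen on an aromatic carbon. Among the compounds with values here, no measured step bears on this change: the single step on record, a 6.8-fold higher number from compound 2 to compound 3 (0.83 log units; beyond the scatter), concerns the group on the saturated chain carbon bound to the carbonyl carbon, not the ring carrying the carboxy group. With nothing comparable measured, no step beyond the scatter is expected, and the estimated step is no change at the digits printed from compound 3 to compound 4 (within the scatter). Compound 4 is therefore estimated at 824 nM in this assay, within a range of 330 nM to 2100 nM.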

Compound 4, half-maximal effective concentration: 608 nM
Compound 4: the middle estimate sits 1.4-fold (0.13 log units) above what was measured; the range from low to high includes it.
By their numbers in this assay, from the lowest: compound 2; then compounds 4 and 3 (each within the scatter of the next).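

Going from 4-carboxyphenyl to 4-carboxy-2-methylphenyl in this assay gives a 1.4-fold lower number from compound 3 to compound 4 (0.13 log units; within the scatter), so this aromatic carbon, ortho to a large group and meta to a carboxy group, carries a methyl without a shift beyond the scatter. Going by these compounds alone, this is the only measured step on this ring, as the earlier step concerned the group on the saturated chain carbon. No measured evidence bears on why the number holds. As far as these compounds go, whether ethyl, methoxy or chlorine at this carbon behaves the same stays open, as does the effect of this methyl alongside the isopropyl group of compound 2.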